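This account rests on a few compounds, and the source may have more. Where it says the series, first, only, none or still open, it means among the compounds named here.

In a functional assay on A549 cells (Homo sapiens) for inhibition, read by MTT assay, with a stated time of 48 h (on this read-out lower numbers stand for stronger inhibition and higher numbers for weaker inhibition), compound 1 (`COc1ccc(/C=C/c2cc(OC)cc(OC)c2/C=C/C(=O)Nc2cc(OC)c(OC)c(OC)c2)cc1`) gives 5140 nM and compound 2 (`CCCCN(CCCC)C(=O)/C=C/c1c(/C=C/c2ccc(OC)cc2)cc(OC)cc1OC`) gives 6160 nM on the same read-out, so compound 2 stands level with compound 1, the two numbers lying within the usual scatter of each other. Compound 3 (`COc1ccc(/C=C/c2cc(OC)cc(OC)c2/C=C/C(=O)N2CCCC(C)C2)cc1`) has yet to be measured. Compared with compound 2 it carries 3-methylpiperidin-1-yl in place of dibutylamino on a carbonyl carbon and the rest of the structure is shared. Going by the values given here, no measured pair differing in one place shows what such a change does, so no shift beyond the scatter is expected in this assay in either direction. This expectation starts from compound 2 at 6160 nM as the nearest reference. The estimate puts a 1.1-fold higher number from compound 2 to compound 3 (0.06 log units; within the scatter) inside the scatter. Compound 3 is expected at 7000 nM with an estimated range of 2500 nM to 20000 nM for its measurement.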

Compound 3, half-maximal inhibitory concentration: 5820 nM
Beside the measured number, compound 3's estimate is 1.2-fold (0.08 log units) above it; measured number inside the range.
By their numbers in this assay, from the lowest: compounds 1, 3 and 2 (each within the scatter of the next).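

In this assay, going by these compounds alone, the one pair differing in a single place gives a 1.1-fold lower number from compound 2 to compound 3 (0.02 log units; within the scatter), with 3-methylpiperidin-1-yl in place of dibutylamino on a carbonyl carbon. Within the data shown here, this is the first reading of a change at this position, and it shows that a group with no ring and one with a six-membered non-aromatic ring stand level here. The finding covers only these two groups, and nothing available accounts for it.

From the compounds shown here alone, whether 4-methylpiperazin-1-yl, which carries a second ring nitrogen, would shift the number beyond the scatter on the same carbonyl carbon remains open. So does whether plain piperidin-1-yl or morpholin-4-yl at this place would read any differently from 3-methylpiperidin-1-yl.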